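The source may report more compounds than this note shows. Statements on the series, on what has been measured and on what is new or still open speak of the compounds shown alone.

Values in a functional assay on HCT-116 cells (Homo sapiens) for inhibition, read by MTT assay, with a stated time of 48 h; on this read-out lower numbers stand for stronger inhibition and higher numbers for weaker inhibition:
- Compound 1 `CCSc1nnc(-c2cc(OC)c(OC)c(OC)c2)n1-c1ccc(N(C)C)cc1`: > 60000 nM (a limit of the assay)
- Compound 2 `COc1cc(-c2nnc(SCc3ccccc3)n2-c2ccc(N(C)C)cc2)cc(OC)c1OC`: 54000 nM (a measured number)
- Compound 3 `COc1cc(-c2nnc(SCc3ccc(F)cc3)n2-c2ccc(N(C)C)cc2)cc(OC)c1OC`: > 60000 nM (a limit of the assay)

Compound 3 gives only a limit and no number, and it sits at the limit of > 60000 nM in this assay, at which 2 of the 3 values shown sit, in this small series. Compound 4 `COc1cc(-c2nnc(SCC(=O)c3ccccc3)n2-c2ccc(N(C)C)cc2)cc(OC)c1OC` carries benzoyl in place of 4-fluorophenyl on a saturated chain carbon bound to a sulfur. Within the data shown here, three measured steps bear on this change. These are an at least 1.1-fold lower number from compound 1 to compound 2 (0.04 log units; that floor lies within the scatter) and an at least 1.1-fold higher number from compound 2 to compound 3 (0.04 log units; that floor lies within the scatter), both with floors inside the scatter, and also a step that the two limits leave unreadable from compound 1 to compound 3 at the same place. No step beyond the scatter is therefore expected in this assay in either direction. The expected change is an at least 1.2-fold lower number from compound 3 to compound 4 (0.07 log units; that floor lies within the scatter) on this estimate. Compound 4 is expected at 50000 nM with an estimated range from 20000 nM to 100000 nM and may return only a limit.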

Compound 4, half-maximal inhibitory concentration: 42500 nM
Estimate against measurement, compound 4: 1.2-fold (0.07 log units) above; the measured number falls inside the stated range.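

In this assay benzoyl on a saturated chain carbon bound to a sulfur gives a measured number, which 4-fluorophenyl at this place did not, yet the floors of both steps involving a limit stay small: an at least 1.4-fold lower number from compound 3 to compound 4 (0.14 log units; that floor lies within the scatter) and an at least 1.4-fold lower number from compound 1 to compound 4 (0.14 log units; that floor lies within the scatter) are the two readings. With a 1.3-fold lower number from compound 2 to compound 4 (0.10 log units; within the scatter) the carbonyl-bearing group also stands level with phenyl, so no change at this place has yet moved the number beyond the scatter. The series stays at the weak end of the read-out: the limit of > 60000 nM in this assay, at which 2 of the 4 values shown sit.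

On these data alone, whether an amine or a carboxylic acid on this chain would give a step beyond the scatter remains open. So does whether any group at this place can bring the number far below those seen here.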